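Acid head-group swap on the cyclopropane carbon

The compounds below may be only part of what the source reports. "The series", "measured", "known", "first", "only" and "open" are said of these compounds alone.

Compound 1 `O=C(O)c1cncc(N2CC(O)(c3ccc(OCc4c(-c5c(Cl)cccc5Cl)noc4C4CC4)cc3Cl)C2)c1` gives 7 nM in an assay on isolated protein for agonist activity at Bile acid receptor (Homo sapiens), read by FRET; on this read-out lower numbers stand for an effect already at smaller amounts and higher numbers for an effect only at larger amounts of compound.
Compound 2 `O=C(O)CNC(=O)c1ccc(C2CC2c2ccc(OCc3c(-c4c(Cl)cccc4Cl)noc3C3CC3)cc2Cl)cc1` gives 150 nM in this assay.
Compound 3 `CC(C)n1nc(C(=O)O)cc1C1CC1c1ccc(OCc2c(-c3c(Cl)cccc3Cl)noc2C2CC2)cc1Cl` gives 7 nM in this assay.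

Compound 3 sits level with compound 1 at the digits shown, the two lowest numbers of the three; the gap between them lies within the scatter. Compound 2 stands furthest away, with a number well beyond the scatter above compound 3.

Compound 4 `O=C(O)c1ccc(C2CC2c2ccc(OCc3c(-c4c(Cl)cccc4Cl)noc3C3CC3)cc2Cl)cn1` is the next entry, not yet measured in this assay. Its structural change from compound 3 is 6-carboxypyridin-3-yl in place of 3-carboxy-1-isopropyl-1H-pyrazol-5-yl on a saturated ring carbon. Both compound 3 and compound 4 carry a carboxylic acid directly on a small aromatic ring at this position, whereas compound 2 carries its acid on a longer glycine amide chain. For the measured compounds named here, with no measured pair that isolates this change, the expectation rests on that likeness to compound 3 rather than to compound 2. A step of a 2.1-fold higher number from compound 3 to compound 4 (0.33 log units; beyond the scatter) is expected, small and within or just beyond the scatter, tending toward a higher number. Compound 4 is therefore estimated at 15 nM, with a range from 5 nM to 60 nM.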

Compound 4, half-maximal effective concentration: 66 nM
Estimate against measurement, compound 4: 4.4-fold (0.64 log units) below; the measured number lies above the stated range.
By their numbers in this assay, from the lowest: compounds 1 and 3 (each within the scatter of the next); then compound 4; then compound 2.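

In this assay this position on a saturated ring carbon proves sensitive to which aromatic acid it carries, with a 9.4-fold higher number from compound 3 to compound 4 (0.97 log units; beyond the scatter) when 6-carboxypyridin-3-yl replaces 3-carboxy-1-isopropyl-1H-pyrazol-5-yl. For the compounds shown here, a carboxylic acid directly on a small aromatic ring is thus not enough by itself to keep the number of compound 3, something the earlier compounds could not show, since no pair among them differed at this place alone. Nothing measured here bears on the reason for this step.

The swap changes the ring, its hetero atoms and the isopropyl group all at once, and the compounds shown do not separate these. From the compounds shown here alone, it remains open how a pyrazole carboxylic acid carrying a methyl group in place of the isopropyl would read at this position.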